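Acetyl for methyl on the ring amine in two cores

The source may report more compounds than this note shows. Statements on the series, on what has been measured and on what is new or still open speak of the compounds shown alone.

Measured so far in an assay on isolated protein for displacement of a labelled ligand from 5-hydroxytryptamine receptor 6 (Homo sapiens), read by scintillation counting, with a stated time of 1 h; a higher number here means a weaker inhibitor, a lower number a stronger inhibitor:
compound 1 `CN1CCN(c2cccc3c2ccn3S(=O)(=O)c2ccccc2)CC1` gives 1 nM
compound 2 `CC(=O)N1CCN(c2cccc3c2ccn3S(=O)(=O)c2ccccc2)CC1` gives 714 nM
compound 3 `CN1CCN(c2ccc3c(ccn3S(=O)(=O)c3ccccc3)c2)CC1` gives 27 nM

Compound 1 and compound 3 carry the same atoms joined differently; the difference between the two cores is not broken down here. Compound 3 gives the second-highest number of the three, beyond the scatter from both others.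

Compound 2 differs from compound 1 only by acetyl in place of methyl on an amine nitrogen in a ring, and that change gave a 710-fold higher number from compound 1 to compound 2 (2.85 log units; beyond the scatter) in this assay.

Compound 4 `CC(=O)N1CCN(c2ccc3c(ccn3S(=O)(=O)c3ccccc3)c2)CC1`, not yet measured, differs from compound 3 by acetyl in place of methyl on an amine nitrogen in a ring. The place is the same in both pairs, so this is the same change made on the core of compound 3. The expectation rests on one pair only, and on compound 3 standing at 27 nM in this assay. The step is expected to be a 370-fold higher number from compound 3 to compound 4 (2.57 log units; beyond the scatter), because the earlier step was a 710-fold higher number from compound 1 to compound 2 (2.85 log units; beyond the scatter), though the count of pairs is too small to know it carries over unchanged. Compound 4 is thus estimated at 10000 nM, with a range from 2000 nM to 50000 nM.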

Compound 4, inhibition constant: 4850 nM
For compound 4 the middle estimate is 2.1-fold (0.31 log units) above the measured one, within the range that was stated.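

In this assay, acetyl in place of methyl on an amine nitrogen in a ring again gives a much higher number on the core of compound 3, with a 180-fold higher number from compound 3 to compound 4 (2.25 log units; beyond the scatter), but the size of the step is not the same on the two cores: the same change on two cores in this assay, a 710-fold higher number (2.85 log units; beyond the scatter) from compound 1 to compound 2 and a 180-fold higher number (2.25 log units; beyond the scatter) from compound 3 to compound 4, 4.0-fold (0.60 log units) apart, beyond the scatter of two such steps. The direction of the change therefore carries over between these two cores, while its size does not carry over unchanged. Two pairs do not show how the size depends on the core, why the steps differ, or whether the same direction would hold on a third core.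

Still open, going by these compounds, is how far the result is tied to acetyl itself, and whether a free amine, ethyl, a longer chain or a sulfonamide on the same ring nitrogen would fall nearer the methyl or the acetyl compounds. Also open, on these data alone, is whether the two cores would separate in the same way for those groups, which would need further matched pairs on both cores.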